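Swapping the amide ring on a nitro-bearing aminothiophene

A few compounds are considered here, and "the series" means these few. Any claim that something is new, unique, unknown or untested is made for them only; others in the source may bear on it.

Three compounds share one core and were tested in a functional assay on A549 cells (Homo sapiens) for cytotoxicity, read by sulforhodamine B assay, with a stated time of 72 h; a higher number here means a weaker inhibitor, a lower number a stronger inhibitor. Compound 1 `Nc1sc(-c2ccccc2)c(-c2ccc(Cl)cc2)c1C(=O)N1CCCC1` gives 5800 nM, compound 2 `Nc1sc(-c2ccc(Cl)cc2)c(-c2ccc(Cl)cc2)c1C(=O)N1CCCC1` gives 890 nM, and compound 3 `Nc1sc(-c2ccc([N+](=O)[O-])cc2)c(-c2ccc(Cl)cc2)c1C(=O)NC1CCCCC1` gives 15000 nM, the highest of the three numbers. Among the compounds with values here, the one measured step, a 6.5-fold lower number from compound 1 to compound 2 (0.81 log units; beyond the scatter), concerns a different part of the molecule and does not bear on the change considered here. Compound 4 `Nc1sc(-c2ccc([N+](=O)[O-])cc2)c(-c2ccc(Cl)cc2)c1C(=O)N1CCCC1` differs from compound 3 by pyrrolidin-1-yl in place of cyclohexylamino on a carbonyl carbon. Compounds 1 and 2 both carry this pyrrolidinyl amide and sit lower than compound 3, but each also differs elsewhere, so this is not a clean comparison. A modest lowering is therefore expected in this assay, a 2.5-fold lower number from compound 3 to compound 4 (0.40 log units; beyond the scatter), with compound 4 estimated at 6000 nM, plausibly between 1500 nM and 25000 nM.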

Compound 4, half-maximal inhibitory concentration: 10700 nM
Compound 4: middle estimate off by 1.8-fold (0.25 log units), on the low side; the range from low to high includes it.
By their numbers in this assay, from the lowest: compound 2; then compounds 1, 4 and 3 (each within the scatter of the next, the first and the last beyond it).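

In this assay, moving to the pyrrolidin-1-yl amide gives a 1.4-fold lower number from compound 3 to compound 4 (0.15 log units; within the scatter) so this carbonyl carbon tolerates either ring without a readable difference. With that amide held fixed, nitro in place of chloro on an aromatic carbon gives a 12-fold higher number from compound 2 to compound 4 (1.08 log units; beyond the scatter) while nitro in place of hydrogen gives a 1.8-fold higher number from compound 1 to compound 4 (0.27 log units; within the scatter) so only chloro stands apart. No measurement offered here explains these steps.

On these data alone, whether the amide swap would stay silent with chloro instead of nitro remains open. So does the effect of a morpholine amide or a longer-chain amide on this carbonyl carbon.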